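Aryl amine swap on the shared core: methoxy to ethyl

The source may hold more compounds than are shown below. What is called first, only, known or untested is meant among the compounds shown, and "the series" means these compounds.

Measured compounds:
compound 1, `COc1ccc(NC2=CC(=O)c3c(nc4n3[C@H]3OC[C@@H](O)[C@H]3OC4)C2=O)cc1`: > 8000 nM
compound 2, `O=C1C=C(Nc2ccc(Br)cc2)C(=O)c2c1nc1n2[C@H]2OC[C@@H](O)[C@H]2OC1`: 3830 nM

In a functional assay on HeLa cells (Homo sapiens) for inhibition, read by sulforhodamine B assay (a higher number here means a weaker inhibitor, a lower number a stronger inhibitor), compound 1 gives > 8000 nM, which is a limit of the assay and not a number. Compound 1 therefore stands at the limit of > 8000 nM in this assay, at which 1 of the 2 values shown sits. In this assay, for the measured compounds named here, compound 2 gives 3830 nM, the only number in the set. Going by the values given here, no step between measured compounds differs in a single place, so the two values can only be read side by side: compound 2 is the one with a number, compound 1 is the one at the limit.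

The next compound, compound 3, is `CCc1ccc(NC2=CC(=O)c3c(nc4n3[C@H]3OC[C@@H](O)[C@H]3OC4)C2=O)cc1`. It differs from compound 1 by ethyl in place of methoxy on an aromatic carbon. With nothing measured for this exact change, no direction can be drawn from the shown values. Compound 3 is expected to stay close to where compound 1 sits, with the step that the limit leaves unreadable from compound 1 to compound 3 taken as none beyond the scatter. For compound 3 the estimate in this assay is 9000 nM, within 3000 nM to 30000 nM, and a result reported only as a limit is about as likely as a number.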

Compound 3, half-maximal inhibitory concentration: 6510 nM
Compound 3: the middle estimate sits 1.4-fold (0.14 log units) above what was measured; the range from low to high includes it.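

In this assay compound 3 gives 6510 nM, which places a number on the (4-ethylphenyl)amino member of the series and shows that this position, para to a large group, can carry ethyl with a measurable value on the shared core. Compound 1 gives > 8000 nM, which is a limit of the assay and not a number. The change from methoxy to ethyl therefore reads only as an at least 1.2-fold lower number from compound 1 to compound 3 (0.08 log units; that floor lies within the scatter), so this pair shows no change beyond the scatter, and the real size of the step stays unknown because of where compound 1 sits: the limit of > 8000 nM in this assay, at which 1 of the 3 values shown sits.

Open, as far as these compounds go, is whether the true gap between the 4-methoxyphenyl and 4-ethylphenyl members is small or large, as a value for compound 1 below the limit of the assay would be needed to settle it. Also open, from the compounds shown here alone, is how this position reads in this assay with other groups in the same place, such as an amine, a carboxylic acid or a longer chain like propyl.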